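The compounds below may be only part of what the source reports. "The series", "measured", "known", "first", "only" and "open" are said of these compounds alone.

Measured so far in an assay on isolated protein for inhibition of kallikrein-7 (Mus musculus), read by fluorescence, with stated times of 10 min and 30 min; on this read-out lower numbers stand for stronger inhibition and higher numbers for weaker inhibition:

Compound 1, `CC1=NC(c2cn(S(=O)(=O)c3ccc(Cl)cc3)c3ccc(C)cc23)CN1`: in this assay compound 1 gives > 100000 nM, which is a limit of the assay and not a number.
Compound 2, `CC1=NC(c2cn(S(=O)(=O)c3ccccc3)c3ccc(C)cc23)CN1`: compound 2 gives 15000 nM.
Compound 3, `CC1=NC(c2cn(S(=O)(=O)c3ccccc3F)c3ccc(C)cc23)CN1`: compound 3 gives 6400 nM.

Of the two numbers shown, compound 2 stands highest; the nearest is compound 3, reached by a 2.3-fold lower number from compound 2 to compound 3 (0.37 log units; beyond the scatter) through fluoro in place of hydrogen on an aromatic carbon. The remaining value, that of compound 1, is the limit of > 100000 nM in this assay, at which 1 of the 3 values shown sits. Measured from it, the steps read an at least 6.6-fold lower number from compound 1 to compound 2 (0.82 log units; beyond the scatter) and an at least 15-fold lower number from compound 1 to compound 3 (1.19 log units; beyond the scatter), both against a limit.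

Compound 4, `CC1=NC(c2cn(S(=O)(=O)c3ccccc3C#N)c3ccc(C)cc23)CN1`, differs from compound 2 by cyano in place of hydrogen on an aromatic carbon. Going by the values given here, the one measured step that bears on this change is a 2.3-fold lower number from compound 2 to compound 3 (0.37 log units; beyond the scatter), where another group replaced hydrogen on an aromatic carbon of the same ring; that step was modest and beyond the scatter. Cyano is not fluoro, and no measured pair shows a cyano group, so the transfer is loose. A modest step toward a lower number in this assay is therefore expected, with a wide margin that also allows no change beyond the scatter.

Compound 4 is expected at 8000 nM, within 2500 nM to 30000 nM. This estimate means a 1.9-fold lower number from compound 2 to compound 4 (0.27 log units; within the scatter).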

Compound 4, half-maximal inhibitory concentration: 11000 nM
Compound 4: middle estimate off by 1.4-fold (0.14 log units), on the low side; measured number inside the range.
By their numbers in this assay, from the lowest: compounds 3, 4 and 2 (each within the scatter of the next, the first and the last beyond it). At a limit, above all of these: compound 1.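

In this assay, cyano on an aromatic carbon ortho to a large group gives a 1.4-fold lower number from compound 2 to compound 4 (0.13 log units; within the scatter), so this change cannot be told apart from hydrogen at this place, whereas fluoro there gave a 2.3-fold lower number from compound 2 to compound 3 (0.37 log units; beyond the scatter). Exchanging the two groups gives a 1.7-fold higher number from compound 3 to compound 4 (0.24 log units; within the scatter), so compound 3 and compound 4 cannot be separated either, and cyano sits within the scatter of both compound 2 and compound 3 while those two lie beyond it from each other. The remaining step, an at least 9.0-fold lower number from compound 1 to compound 4 (0.95 log units; beyond the scatter), is only a bound, as compound 1 stands at a limit and not at a number: the limit of > 100000 nM in this assay, at which 1 of the 4 values shown sits.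

From the compounds shown here alone, whether an amine, a methoxy group or a carboxylic acid on this same aromatic carbon would give a step from compound 2 beyond the scatter stays open. Also open, going by these compounds, is whether a 2-chlorophenyl group would follow the 2-fluorophenyl and 2-cyanophenyl groups of compound 3 and compound 4, or the 4-chlorophenyl group of compound 1, which would help separate the effect of the chloro group from that of its place.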